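Pyrimidin-2-yl in place of ethyl: compound 4 expected

The source may hold more compounds than are shown below. What is called first, only, known or untested is meant among the compounds shown, and "the series" means these compounds.

In a functional assay on MCF7 cells (Homo sapiens) for antiproliferative activity, read by sulforhodamine B assay, with a stated time of 48 h (a lower number here means a stronger inhibitor, a higher number a weaker inhibitor), compound 2 (`CCN1CCN(C(=O)/C=C/C=C/[C@H](O)Cc2ccc(OC)c(OC)c2)CC1`) reads 11500 nM and compound 1 (`COc1ccc(C[C@@H](O)/C=C/C=C/C(=O)N2CCN(c3ccccc3)CC2)cc1OC`) reads 12000 nM with no real separation between them. Compound 3 (`COc1ccc(C[C@@H](O)/C=C/C=C/C(=O)N2CCCC2)cc1OC`) reads 26200 nM and stands apart from that pair (a 2.3-fold higher number from compound 2 to compound 3 (0.36 log units; beyond the scatter)). Compound 4 (`COc1ccc(C[C@@H](O)/C=C/C=C/C(=O)N2CCN(c3ncccn3)CC2)cc1OC`) carries pyrimidin-2-yl in place of ethyl on an amine nitrogen in a ring. For the measured compounds named here, the closest precedent is compound 1 with phenyl on that nitrogen (a 1.0-fold lower number from compound 1 to compound 2 (0.02 log units; within the scatter)). The step to compound 3 replaces the whole 4-ethylpiperazin-1-yl and bears less directly. Going by the values given here, no pyrimidin-2-yl compound has been measured yet. In this assay the expected outcome is a 1.0-fold higher number from compound 2 to compound 4 (0.02 log units; within the scatter) and so no shift beyond the scatter. The estimated value for compound 4 is 12000 nM (expected range 6000 nM to 24000 nM).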

Compound 4, half-maximal inhibitory concentration: 14700 nM
The estimate for compound 4 lay 1.2-fold (0.09 log units) below the measured number; low and high end bracket the measured number.
By their numbers in this assay, from the lowest: compounds 2, 1, 4 and 3 (each within the scatter of the next, the first and the last beyond it).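

Placing pyrimidin-2-yl on the amine nitrogen in a ring brings in hydrogen-bond acceptors and an aromatic ring with hetero atoms, yet in this assay neither step leaves the scatter (a 1.3-fold higher number from compound 2 to compound 4 (0.11 log units; within the scatter); a 1.2-fold higher number from compound 1 to compound 4 (0.09 log units; within the scatter)). Ethyl, phenyl and pyrimidin-2-yl therefore cannot be told apart at this position, and the ring nitrogens that distinguish pyrimidin-2-yl from phenyl leave no measurable mark. No evidence bears on why these numbers stay together.

From the compounds shown here alone, whether a carboxylic acid or a primary amine carried on a longer chain at this nitrogen would separate from these three groups remains open.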